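A few compounds are considered here, and "the series" means these few. Any claim that something is new, unique, unknown or untested is made for them only; others in the source may bear on it.

Working notes on the series. Going by the values given here, compound 1 `O=C(CO[N+](=O)[O-])Nc1ccc(C(=O)/C=C/c2ccco2)cc1` gives 48% in a functional assay on the whole organism (strain albino) for inhibition, with Rattus norvegicus as the target, read by paw edema, with stated times of 30 min and 3 h, at a dose of 100 mg/kg by the oral route (on this read-out lower numbers stand for less inhibition and higher numbers for more inhibition at the one dose given (going by the name of the read-out)), and stands lowest of the two numbers measured so far, though its nearest neighbour is within the scatter. Compound 2 `CC(O[N+](=O)[O-])C(=O)Nc1ccc(C(=O)/C=C/c2ccco2)cc1` gives 54% in this assay, and the step of a number 6 percentage points higher from compound 1 to compound 2 (within the scatter) comes with a methyl in place of hydrogen on a saturated chain carbon bound to a carbonyl carbon and an oxygen on an unsaturated carbon. Compound 3 `CC(=O)c1ccc(OCC(=O)Nc2ccc(C(=O)/C=C/c3ccco3)cc2)cc1` is not yet measured. It differs from compound 1 as follows: 4-acetylphenyl in place of nitro on an oxygen on a saturated carbon. Among the compounds with values here, no measured step touches the group on that oxygen; the only step recorded, from compound 1 to compound 2, changes a chain carbon and lies within the scatter, so it says little about 4-acetylphenyl replacing nitro. Without a bearing step the expectation is anchored on compound 1 alone and left broad. Compound 3 is therefore estimated at 45% in this assay, between 20% and 65%, which is an expected step of a number 3 percentage points lower from compound 1 to compound 3 (within the scatter).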

Compound 3, a percentage reported as inhibition, in the whole organism at one dose (the size of the read-out at that dose, not a potency): 45%
Beside the measured number, compound 3's estimate shows no gap at the digits printed, and the stated range covers the measured number.
By their numbers in this assay, from the lowest: compounds 3, 1 and 2 (each within the scatter of the next).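

This position, on an oxygen on a saturated carbon, now has a measured change: in this assay the 4-acetylphenyl in place of nitro gives a number 3 percentage points lower from compound 1 to compound 3 (within the scatter). The read-out therefore stays within the scatter when the nitro group leaves and a group with more heavy atoms and a six-membered aromatic ring of carbon only enters, so in this pair the nitro group is not required for inhibition at the one dose given. Nothing measured explains this result.

Open is whether the acetyl matters to this outcome, since the compounds shown do not include an unsubstituted phenyl or a ring carrying an amine or a carboxylic acid in its place. Also open, on these data alone, is whether a methyl on the chain carbon, as in compound 2, would change the read-out when 4-acetylphenyl is present.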